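Acetyl for 1-chloroethyl on the side chain of compound 1

A few compounds are considered here, and "the series" means these few. Any claim that something is new, unique, unknown or untested is made for them only; others in the source may bear on it.

Compound 1 `CC(Cl)CC(=O)NC1=C(C#N)C(c2ccc(Cl)cc2Cl)C2=C(CCCC2=O)N1c1ccc(S(N)(=O)=O)cc1` holds the second highest of the three measured numbers: in a functional assay on Ehrlich cells (Mus musculus) for cytotoxicity, read by trypan blue exclusion, with a stated time of 2 h, tested at 10 ug/mL (on this read-out higher numbers stand for a stronger effect at the one concentration tested and lower numbers for a weaker effect), compound 1 gives 20%. Compound 2 `N#CC1=C(NC(=O)c2ccccc2)N(c2ccc(S(N)(=O)=O)cc2)C2=C(C(=O)CCC2)C1c1ccc(Cl)cc1Cl` gives 50% in this assay, and compound 3 `CN(C)c1ccc(/C=N/C2=C(C#N)C(c3ccc(Cl)cc3Cl)C3=C(CCCC3=O)N2c2ccc(S(N)(=O)=O)cc2)cc1` gives 10%. The nearest neighbour of compound 1 is compound 3, the furthest is compound 2.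

Compound 4 `CC(=O)CC(=O)NC1=C(C#N)C(c2ccc(Cl)cc2Cl)C2=C(CCCC2=O)N1c1ccc(S(N)(=O)=O)cc1` is the next member, differing from compound 1 by acetyl in place of 1-chloroethyl on a saturated chain carbon bound to a carbonyl carbon; read one bond further out, 2-chloropropyl becomes 2-oxopropyl while the carbonyl and the rest of the shared core are kept.

Among the compounds with values here, no measured step exchanges 1-chloroethyl for acetyl, so none bears on this change directly. The steps that touch the same carbonyl are a number 30 percentage points higher from compound 1 to compound 2 (beyond the scatter) and a number 10 percentage points lower from compound 1 to compound 3 (within the scatter); both replace the whole 2-chloropropyl rather than one atom within it, and only the first is beyond the scatter, while a number 40 percentage points lower from compound 2 to compound 3 (beyond the scatter) concerns two groups absent from compound 4. A change confined to one chain atom is therefore expected to give a step in this assay no larger than the scatter, in either direction.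

For compound 4 the expected value in this assay is 20%, estimated to lie between 5% and 40%. The expected step of no change at the digits printed from compound 1 to compound 4 (within the scatter) is thus within the scatter.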

Compound 4, a percentage reported as activity, at one concentration (the size of the read-out at that concentration, not a potency): 40%
The estimate for compound 4 lay 20 percentage points below the measured number; measured number inside the range.
By their numbers in this assay, from the lowest: compounds 3 and 1 (each within the scatter of the next); then compounds 4 and 2 (each within the scatter of the next).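

In this assay the exchange of acetyl for 1-chloroethyl on a saturated chain carbon bound to a carbonyl carbon gives a number 20 percentage points higher from compound 1 to compound 4 (beyond the scatter) and thus shows that a change within the side chain, at an equal count of heavy atoms, can move the read-out beyond the scatter, something the earlier replacements of whole groups could not show. Against the larger group of compound 3, the group of compound 4 gives a number 30 percentage points higher from compound 3 to compound 4 (beyond the scatter) on the double-bonded ring carbon, while 2-oxopropyl in place of phenyl gives a number 10 percentage points lower from compound 2 to compound 4 (within the scatter) on the carbonyl carbon, so these two quite different groups do not separate on this read-out. Nothing at hand explains the effect of the acetyl exchange.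

From the compounds shown here alone, it remains open whether the step follows the entering carbonyl oxygen or the leaving chlorine, a question that a plain propyl or a 2-hydroxypropyl on the same carbonyl would address. Going by these compounds, a longer chain, or an amine or carboxylic acid at the end of the chain, also remains open, and the read-out speaks only of a stronger or weaker effect at the one concentration tested.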